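Taking the fluoro group off compound 1

This account rests on a few compounds, and the source may have more. Where it says the series, first, only, none or still open, it means among the compounds named here.

Compound 1 `C/C(=N\NC(=S)Nc1cccc(F)c1)c1ccccn1`: 12 nM
Compound 2 `CC(=NNC(=S)Nc1cccc(F)c1)c1ccccn1`: 12 nM
Compound 3 `CC(=NNC(=S)Nc1ccccc1[N+](=O)[O-])c1ccccn1`: 6.6 nM

In a functional assay on T98G cells (Homo sapiens) for cytotoxicity, read by MTT assay, with a stated time of 48 h (a higher number here means a weaker inhibitor, a lower number a stronger inhibitor), compound 1 gives 12 nM and stands level with compound 2 at 12 nM, while compound 3 at 6.6 nM lies within the scatter of both. The change followed here leads to compound 4 `C/C(=N\NC(=S)Nc1ccccc1)c1ccccn1` and reads (hydrogen in place of fluoro on an aromatic carbon), with hydrogen in place of fluoro on an aromatic carbon.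

For the measured compounds named here, only one measured step starts from compound 1, namely no change at the digits printed from compound 1 to compound 2 (within the scatter). It concerns the fact that one of compounds 1 and 2 is drawn with a defined configuration and the other without, at the place where they differ and leaves the fluoro in place, so it offers only a weak guide to this change. Compound 3 also has no fluoro and, at 6.6 nM, still sits within the scatter of compound 1.

No shift beyond the scatter is therefore expected in this assay, and the expected step is a 1.1-fold lower number from compound 1 to compound 4 (0.04 log units; within the scatter). The estimate for compound 4 is 11 nM, with an expected range from 4 nM to 30 nM.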

Compound 4, half-maximal inhibitory concentration: 6.81 nM
Compound 4: middle estimate off by 1.6-fold (0.21 log units), on the high side; the range from low to high includes it.
By their numbers in this assay, from the lowest: compounds 3, 4, 1 and 2 (each within the scatter of the next).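

In this assay, hydrogen in place of fluoro on an aromatic carbon, meta to a large group, gives a 1.8-fold lower number from compound 1 to compound 4 (0.25 log units; within the scatter), so the fluoro can be removed from this position without a shift beyond the scatter. For the compounds shown here, this is the first direct reading of a change at this position, as the earlier step from compound 1 left the fluoro in place and touched only how the double bond is drawn. Nothing available bears on why this exchange behaves as it does.

With only fluoro and hydrogen compared at this position, the compounds shown leave open whether a methoxy group, an amine or a carboxylic acid on the same carbon would also stay within the scatter. They also leave open whether this tolerance would hold for a chloro or a methyl group there.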